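Trading an isobutyl ester for a free acid

The source may report more compounds than this note shows. Statements on the series, on what has been measured and on what is new or still open speak of the compounds shown alone.

Compound 1 `CC(C)COC(=O)c1cc(CN2CCCC2)c(O)c(CN2CCCC2)c1` and compound 3 `CC(C)COC(=O)CCc1cc(CN2CCCC2)c(O)c(CN2CCCC2)c1` share one core; they differ by 2-(isobutoxycarbonyl)ethyl in place of isobutoxycarbonyl on an aromatic carbon. In a functional assay for inhibition, with Cavia porcellus as the target (a higher number here means that more compound is needed for the effect, a lower number that less compound is needed), compound 1 gives 2.3 ug/mL, while compound 3 gives 14 ug/mL, a step of a 6.1-fold higher number from compound 1 to compound 3 (0.78 log units; beyond the scatter). Compound 2 `O=C(O)c1cc(CN2CCCC2)c(O)c(CN2CCCC2)c1` differs from compound 1 by hydrogen in place of isobutyl on an oxygen next to a carbonyl group. In this assay compound 2 reaches only a limit, > 30 ug/mL. Going by these compounds, the step is an at least 13-fold higher number from compound 1 to compound 2 (1.11 log units; beyond the scatter), and its full size is unknown because the limit of > 30 ug/mL in this assay, at which 1 of the 3 values shown sits, caps what was recorded. Compound 4 `O=C(O)CCc1cc(CN2CCCC2)c(O)c(CN2CCCC2)c1` carries the same change on compound 3, namely (hydrogen in place of isobutyl on an oxygen next to a carbonyl group), at a place described in identical words. Because the earlier step was an at least 13-fold higher number from compound 1 to compound 2 (1.11 log units; beyond the scatter), compound 4 is expected to shift by an 8.6-fold higher number from compound 3 to compound 4 (0.93 log units; beyond the scatter). Compound 4 is therefore estimated at 120 ug/mL, likely reported only as a limit, somewhere between 30 ug/mL and 500 ug/mL.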

Compound 4, concentration for half-maximal effect: > 1000 ug/mL
Compound 4 was reported as a limit; the forecaster's own chance of this, stated with the estimate: 85%; at least 8.3-fold (0.92 log units) between middle value and limit.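

In this assay compound 4 reaches only a limit, > 1000 ug/mL. Putting hydrogen in place of isobutyl on this core gives an at least 71-fold higher number from compound 3 to compound 4 (1.85 log units; beyond the scatter), and the whole change from the shorter ester to the longer acid gives an at least 430-fold higher number from compound 1 to compound 4 (2.63 log units; beyond the scatter). The change therefore raises the number on both cores, but nothing shows that its size carries over, and the step between the two acids cannot be read, as both are limits: the same change on two cores in this assay, an at least 13-fold higher number (1.11 log units; beyond the scatter) from compound 1 to compound 2 and an at least 71-fold higher number (1.85 log units; beyond the scatter) from compound 3 to compound 4; the limit leaves it open whether they differ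

The compounds shown leave open whether any group on that oxygen would keep the effect or whether isobutyl is special. A methyl ester, or an amide in place of the ester, on either core would help to separate these possibilities.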